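Fluoro to methoxy on a weakly active compound

A few compounds are considered here, and "the series" means these few. Any claim that something is new, unique, unknown or untested is made for them only; others in the source may bear on it.

Compound 1 `C=C(Br)C(=O)Nc1ccc(/C=C/C(=O)c2ccc(F)cc2)cc1` gives 660 nM
Compound 2 `C=C(Br)C(=O)Nc1ccc(C(=O)/C=C/c2ccc(OC)c(OC)c2OC)cc1` gives 680 nM
Compound 3 `Nc1ccc(/C=C/C(=O)c2ccc(F)cc2)cc1` gives 12000 nM

Compound 3 has the highest number of the three in a functional assay on MOLT-4 cells (Homo sapiens) for antiproliferative activity, with a stated time of 48 h (a higher number here means a weaker inhibitor, a lower number a stronger inhibitor), and is therefore the weakest inhibitor here, beyond the scatter from both of the others.

Compound 4 `COc1ccc(C(=O)/C=C/c2ccc(N)cc2)cc1` differs from compound 3 in one place: methoxy in place of fluoro on an aromatic carbon (methoxy in place of fluoro on an aromatic carbon, para to a large group).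

For the measured compounds named here, only one measured step is available, and it concerns a different part of the molecule. This step, an 18-fold higher number from compound 1 to compound 3 (1.26 log units; beyond the scatter), is large and replaces (1-bromoethenyl)carbonyl with hydrogen on a nitrogen on an aromatic ring. Compound 4 has that same hydrogen, so the step says nothing directly about the exchange of fluoro for methoxy. Going by the values given here, no measured pair shows that exchange, which leaves compound 3 at 12000 nM as the only close reference point, and the range must stay wide.

The estimated change is no change at the digits printed from compound 3 to compound 4 (within the scatter) and so no step beyond the scatter is expected in this assay in either direction. For compound 4 the expected value is 12000 nM with an estimated range from 4000 nM to 35000 nM in this measurement.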

Compound 4, half-maximal inhibitory concentration: 19000 nM
Estimate against measurement, compound 4: 1.6-fold (0.20 log units) below; measured number inside the range.
By their numbers in this assay, from the lowest: compounds 1 and 2 (each within the scatter of the next); then compounds 3 and 4 (each within the scatter of the next).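

Putting methoxy in place of fluoro on this aromatic carbon, para to a large group, gives a 1.6-fold higher number from compound 3 to compound 4 (0.20 log units; within the scatter) in this assay and so the two groups cannot be told apart here. A larger group carrying a hydrogen-bond acceptor can therefore sit at this carbon without a step beyond the scatter, at least while the nitrogen carries only hydrogen, whereas the change on that nitrogen gives an 18-fold higher number from compound 1 to compound 3 (1.26 log units; beyond the scatter) and does lie beyond the scatter. No measurement shown here gives a reason for either result.

On these data alone, both compounds in the new step have hydrogen on the nitrogen, so it remains open whether the same exchange would also leave the number within the scatter with (1-bromoethenyl)carbonyl on that nitrogen, the group carried by compound 1 at 660 nM in this assay. As far as these compounds go, it also remains open how this carbon would respond to other groups, such as chloro, hydroxy or the longer ethoxy chain, since two groups that cannot be told apart do not show how much change the position accepts.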